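Benzyl to Trifluoromethylphenyl: an Expected Solubility Shift

The compounds below may be only part of what the source reports. "The series", "measured", "known", "first", "only" and "open" are said of these compounds alone.

Measured so far:
Compound 1 `COc1ccc(F)cc1CNCCCNc1ccnc2cc(Oc3cccc(N(C)C)c3)ccc12`: 14500 nM
Compound 2 `COc1ccc(F)cc1CNCCCNc1ccnc2cc(Cc3ccccc3)ccc12`: 4200 nM

In a physicochemical assay for solubility, with a stated time of 18 h, at pH 7.4 (on this read-out lower numbers stand for lower solubility and higher numbers for higher solubility), compound 2 stands lowest of the two numbers. Compound 1 lies higher: the change was a 3.5-fold lower number from compound 1 to compound 2 (0.54 log units; beyond the scatter), a modest step beyond the scatter. Compound 3 `COc1ccc(F)cc1CNCCCNc1ccnc2cc(-c3ccc(C(F)(F)F)cc3)ccc12` differs from compound 2 by 4-(trifluoromethyl)phenyl in place of benzyl on an aromatic carbon. Among the measured compounds shown here, no measured step tracks this exact change; the single step of a 3.5-fold lower number from compound 1 to compound 2 (0.54 log units; beyond the scatter) concerns a different group and shows only that the substituent at this position moves the read-out. The number for compound 3 is therefore expected to fall, by roughly a 2.8-fold lower number from compound 2 to compound 3 (0.45 log units; beyond the scatter), with wide uncertainty. The estimate for compound 3 is 1500 nM, within 400 nM to 6000 nM.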

Compound 3, solubility: 32000 nM
The estimate for compound 3 lay 21-fold (1.33 log units) below the measured number; measured number above the stated range.
By their numbers in this assay, from the lowest: compound 2; then compound 1; then compound 3.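

In this assay the swap of benzyl for 4-(trifluoromethyl)phenyl on this aromatic carbon gives a 7.6-fold higher number from compound 2 to compound 3 (0.88 log units; beyond the scatter) and so shows that the number at this position can rise well past that of the other two compounds, not only fall. Replacing 3-(dimethylamino)phenoxy with the same group gives a 2.2-fold higher number from compound 1 to compound 3 (0.34 log units; beyond the scatter) and leaves compound 3 with the highest of the three numbers. Nothing measured here explains the rise. The compounds shown leave open whether the trifluoromethyl group or the directly attached phenyl ring carries this step, and how a plain phenyl or a phenyl bearing a carboxylic acid would read at this carbon.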